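Replacing the side chain of compound 3

The source may report more compounds than this note shows. Statements on the series, on what has been measured and on what is new or still open speak of the compounds shown alone.

Compound 1 `CC(=O)NC1=CS(=O)(=O)O[C@@]12[C@@H](CO[Si](C)(C)C(C)(C)C)O[C@@H](n1cc(C)c(=O)n(C)c1=O)[C@@H]2O[Si](C)(C)C(C)(C)C`: > 200000 nM, a limit
Compound 2 `Cc1cn([C@@H]2O[C@@H]3COC(=O)[C@]3(OS(C)(=O)=O)[C@H]2O)c(=O)[nH]c1=O`: >= 36000 nM, a limit
Compound 3 `COC(=O)CC(=O)NC1=CS(=O)(=O)O[C@@]12[C@@H](CO[Si](C)(C)C(C)(C)C)O[C@@H](n1cc(C)c(=O)n(C)c1=O)[C@@H]2O[Si](C)(C)C(C)(C)C`: 29000 nM

Among the measured compounds shown here, in a functional assay on HEL cells (Homo sapiens) (a higher number here means that more compound is tolerated, a lower number that less compound is tolerated), compound 3 gives 29000 nM, the only exact number. The other two values are limits. Compound 4 `Cc1cn([C@@H]2O[C@H](CO[Si](C)(C)C(C)(C)C)[C@@]3(OS(=O)(=O)C=C3NCC(=O)C(N)=O)[C@H]2O[Si](C)(C)C(C)(C)C)c(=O)n(C)c1=O` differs from it in one place: (carbamoylcarbonyl)methyl in place of ((methoxycarbonyl)methyl)carbonyl on an amine nitrogen. For the measured compounds named here, the one measured step that bears on this chain is an at least 6.8-fold lower number from compound 1 to compound 3 (0.83 log units; beyond the scatter), and it came with adding methoxycarbonyl. On these data alone, compound 4 no longer carries that methoxycarbonyl, so part of that step may reverse, although the entering chain is untested. The expected result is a 2.8-fold higher number from compound 3 to compound 4 (0.44 log units; beyond the scatter), towards more compound tolerated. For compound 4 the estimate is 80000 nM, with an expected range of 25000 nM to 200000 nM.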

Compound 4, half-maximal cytotoxic concentration: 14500 nM
For compound 4 the middle estimate is 5.5-fold (0.74 log units) above the measured one; the measured number lies below the stated range.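

In this assay, putting (carbamoylcarbonyl)methyl in place of ((methoxycarbonyl)methyl)carbonyl on the amine nitrogen gives a 2.0-fold lower number from compound 3 to compound 4 (0.30 log units; within the scatter), so the two chains cannot be told apart here and the methoxycarbonyl group is not needed to keep the number this low. Against the acetyl group the new chain gives an at least 13-fold lower number from compound 1 to compound 4 (1.13 log units; beyond the scatter), so a second, different chain also sits clearly below the acetyl compound. That comparison rests on a limit for compound 1: the limit of > 200000 nM in this assay, at which 1 of the 4 values shown sits.

Still open, on these data alone, is whether a carboxylic acid or a simple amine at the end of this chain would hold the number. As far as these compounds go, a longer chain is equally open.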